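Two limits and a hydroxyphenyl step

The source may report more compounds than this note shows. Statements on the series, on what has been measured and on what is new or still open speak of the compounds shown alone.

Measured in a functional assay on DU-145 cells (Homo sapiens) for antiproliferative activity, read by MTT assay, with a stated time of 48 h; on this read-out higher numbers stand for weaker inhibition and lower numbers for stronger inhibition:
- Compound 1 `C/C(=C\CC/C(C)=C/CC[C@@H]1[C@@]2(C)CCC(=O)C(C)(C)[C@H]2CC[C@@]1(C)O)CC/C=C(\C)C(=O)OCc1cn(-c2cccc([N+](=O)[O-])c2)nn1`: > 150000 nM, a limit
- Compound 2 `C/C(=C\CC/C(C)=C/CC[C@@H]1[C@@]2(C)CCC(=O)C(C)(C)[C@H]2CC[C@@]1(C)O)CC/C=C(\C)C(=O)OCc1cn(-c2ccccc2Cl)nn1`: > 150000 nM, a limit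

Compound 2 gives no number, only its limit of > 150000 nM. For the measured compounds named here, the series so far consists of the limit of > 150000 nM in this assay, at which 2 of the 2 values shown sit. Going by the values given here, the one measured step is a step that the two limits leave unreadable from compound 1 to compound 2, so no size can be carried forward from it.

Compound 3 `C/C(=C\CC/C(C)=C/CC[C@@H]1[C@@]2(C)CCC(=O)C(C)(C)[C@H]2CC[C@@]1(C)O)CC/C=C(\C)C(=O)OCc1cn(-c2cccc(O)c2)nn1` has 3-hydroxyphenyl in place of 2-chlorophenyl on an aromatic nitrogen. With no readable step behind it, no clear change in this assay is expected in either direction, and a further limit is the likeliest result.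

The expected step is a number no higher from compound 2 to compound 3 (the limit leaves the size open). For compound 3 the estimate is 150000 nM, with an expected range of 60000 nM to 300000 nM.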

Compound 3, half-maximal inhibitory concentration: 28400 nM
Estimate against measurement, compound 3: 5.3-fold (0.72 log units) above; measured number outside the range, below it.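

In this assay the group on the aromatic nitrogen does change the read-out: 3-hydroxyphenyl in place of 2-chlorophenyl gives an at least 5.2-fold lower number from compound 2 to compound 3 (0.72 log units; beyond the scatter). Hydroxy in place of nitro on an aromatic carbon gives an at least 5.2-fold lower number from compound 1 to compound 3 (0.72 log units; beyond the scatter). Both sizes are only minimum sizes set by limits, and compound 3 is the only one of the three with a number.

The compounds shown leave open how large the true gaps are. They also leave open whether an amine or a methoxy group on that same aromatic carbon would match hydroxy.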